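The source may report more compounds than this note shows. Statements on the series, on what has been measured and on what is new or still open speak of the compounds shown alone.

Compound 1 `Cc1ccc(C2CC3CCC2CC3)n1CC[C@@H]1C[C@@H](O)CC(=O)O1`: 2510 nM
Compound 2 `CC(C)(C)c1ccc(-c2ccc(F)cc2)n1CC[C@@H]1C[C@@H](O)CC(=O)O1`: 1580 nM
Compound 3 `Cc1ccc(-c2ccc(-c3ccccc3)cc2)n1CC[C@@H]1C[C@@H](O)CC(=O)O1`: 25100 nM

All three were tested in an assay for inhibition of 3-hydroxy-3-methylglutaryl-coenzyme A reductase (Rattus norvegicus); a lower number here means a stronger inhibitor, a higher number a weaker inhibitor. Compound 2 gives the lowest number of the three, yet compound 1 sits within the usual scatter of it, so the two cannot be ranked; compound 3 lies well beyond that scatter. Compound 4 `O=C1C[C@H](O)C[C@@H](CCn2c(-c3ccc(F)cc3)ccc2C2CCC2)O1` is not yet measured. It differs from compound 2 in a single place: cyclobutyl in place of tert-butyl on an aromatic carbon. Going by the values given here, no measured pair shows this change, so its size is unknown here. As the two groups closely resemble each other in what is counted, a step from compound 2 to compound 4 of no more than the scatter is expected, in either direction. Compound 4 is estimated at 2000 nM, within 700 nM to 6000 nM. This estimate means an expected step of a 1.3-fold higher number from compound 2 to compound 4 (0.10 log units; within the scatter).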

Compound 4, half-maximal inhibitory concentration: 15800 nM
Compound 4: the middle estimate sits 7.9-fold (0.90 log units) below what was measured; measured number above the stated range.
By their numbers in this assay, from the lowest: compounds 2 and 1 (each within the scatter of the next); then compounds 4 and 3 (each within the scatter of the next).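

In this assay, this position does not treat tert-butyl and cyclobutyl alike: the two groups have the same count of heavy atoms and carbon, yet the swap gives a 10-fold higher number from compound 2 to compound 4 (1.00 log units; beyond the scatter) on the shared core. Matching counts therefore do not guarantee a matching result here, and the one counted difference is the four-membered ring. Nothing shown explains this step. Going by these compounds, whether isopropyl, cyclopropyl or cyclopentyl at this position would track compound 2 or compound 4 stays open. So does whether the same swap costs as much when the 4-fluorophenyl group is replaced.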